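Removing the Benzyl Ester from Compound 1

A few compounds are considered here, and "the series" means these few. Any claim that something is new, unique, unknown or untested is made for them only; others in the source may bear on it.

Measured compounds:
compound 1, `CC[C@H](C)[C@H](NC(=O)CN(c1nc(Cl)nc2[nH]cnc12)C1CC1)C(=O)OCc1ccccc1`: 6.9%
compound 2, `O=C(CN(c1nc(Cl)nc2[nH]cnc12)C1CC1)N[C@@H](CCC(=O)OCc1ccccc1)C(=O)OCc1ccccc1`: 44.5%
compound 3, `NC(=O)C[C@H](NC(=O)CN(c1nc(Cl)nc2[nH]cnc12)C1CC1)C(=O)OCc1ccccc1`: 13.5%

All three were tested in a functional assay on the whole organism (Tail, strain ICR) with Mus musculus as the target, in the tail flick test, with a stated time of 150 min, at a dose of 25 umol/kg by the oral route; on this read-out lower numbers stand for a weaker effect and higher numbers for a stronger effect at the one dose given. Compound 1 stands lowest of the three numbers. Its nearest neighbour is compound 3, and that gap is within the scatter (a number 6.6 percentage points higher from compound 1 to compound 3 (within the scatter)). Its furthest neighbour is compound 2, reached by a large step (a number 37.6 percentage points higher from compound 1 to compound 2 (beyond the scatter)). Between the two larger side chains there is again a large step (a number 31 percentage points lower from compound 2 to compound 3 (beyond the scatter)).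

Compound 4 `CC[C@H](C)[C@H](NC(=O)CN(c1nc(Cl)nc2[nH]cnc12)C1CC1)C(=O)O` keeps the whole shared core and differs from compound 1 in a single place: hydrogen in place of benzyl on an oxygen next to a carbonyl group. For the measured compounds named here, none of the measured steps changes this position; all three alter the side chain on the saturated chain carbon bound to an amide-type nitrogen and a carbonyl carbon, or a group two bonds along that chain. Going by the values given here, the only measured step in which a benzyl-bearing ester group also leaves the molecule is a number 31 percentage points lower from compound 2 to compound 3 (beyond the scatter), but that concerns a different place, so it gives no direct guide. Among the compounds with values here, with compound 1 already the lowest number and no step bearing on the ester, no step beyond the scatter is expected (a number 1.1 percentage points higher from compound 1 to compound 4 (within the scatter)). Compound 4 is therefore estimated at 8%, in the range 0% to 25%.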

Compound 4, a percentage reported as activity, at one dose (the size of the read-out at that dose, not a potency): 6.71%
The estimate for compound 4 lay 1.3 percentage points above the measured number; the measured number falls inside the stated range.
By their numbers in this assay, from the lowest: compounds 4, 1 and 3 (each within the scatter of the next); then compound 2.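

In this assay, for the compounds shown here, hydrogen in place of benzyl on an oxygen next to a carbonyl group, which turns benzyloxycarbonyl into carboxy, gives a step that reads a number 0.2 percentage points lower from compound 1 to compound 4 (within the scatter) and is the first reading at this position, as the earlier steps all changed the side chain or a group along it. With the sec-butyl side chain kept, the whole benzyl group and its aromatic ring can leave and the two compounds still cannot be told apart on this read-out, so in this pair the number does not depend on the benzyl group. Both compounds sit close to the low end of the numbers seen so far, and nothing at hand explains why the change leaves the result in the scatter.

The compounds shown leave open whether the same exchange would behave alike on a side chain with a clearly higher number, such as that of compound 2, which carries a benzyl ester at this position and a second one further along its chain. They also leave open what a methyl ester, an ethyl ester or a primary amide would do at this position.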